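Working notes: tetrazolyl for triazolyl on sulfur, compound 4

The compounds below may be only part of what the source reports. "The series", "measured", "known", "first", "only" and "open" are said of these compounds alone.

Measured in a functional assay on C6 cells (Rattus norvegicus) for cytotoxicity, read by MTT assay, with a stated time of 24 h, tested at 200 ug/mL; on this read-out higher numbers stand for a weaker effect at the one concentration tested and lower numbers for a stronger effect:
compound 1, `Cc1ccc(-c2cs/c(=N/NC(=O)CSc3nnnn3-c3ccccc3)n2-c2ccccc2)cc1`, gives 22.2%
compound 2, `Cc1ccc(-c2cs/c(=N/NC(=O)CSc3nncn3C)n2-c2ccccc2)cc1`, gives 27.8%
compound 3, `Cn1cnnc1SCC(=O)N/N=c1/scc(-c2ccccc2)n1-c1ccccc1`, gives 35.5%

Compound 4, `O=C(CSc1nnnn1-c1ccccc1)N/N=c1/scc(-c2ccccc2)n1-c1ccccc1`, has not yet been measured in this assay. It differs from compound 3 in one place: 1-phenyl-1H-tetrazol-5-yl in place of 4-methyl-4H-1,2,4-triazol-3-yl on a sulfur. The same change has already been made once within the measured set, from compound 2 to compound 1: 1-phenyl-1H-tetrazol-5-yl in place of 4-methyl-4H-1,2,4-triazol-3-yl on a sulfur. That step reads a number 5.6 percentage points lower from compound 2 to compound 1 (within the scatter). The two places are described in the same words, a sulfur whose other neighbours are a saturated chain carbon, so the change from compound 3 to compound 4 is the same kind of change made on a different core.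

The cores of the two pairs differ as follows: hydrogen in place of methyl on an aromatic carbon. That difference on its own gave a number 7.7 percentage points higher from compound 2 to compound 3 (within the scatter). For the measured compounds named here, compound 3 holds the highest of the three numbers; its value and that of compound 1 lie apart by more than the scatter, but no single-change step links them.

Because the earlier step of a number 5.6 percentage points lower from compound 2 to compound 1 (within the scatter) was small, a step of similar size is expected from compound 3 to compound 4, namely a number 5.5 percentage points lower from compound 3 to compound 4 (within the scatter). Compound 4 is therefore estimated at 30% in this assay, with a range expected from 20% to 40%.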

Compound 4, a percentage reported as activity, at one concentration (the size of the read-out at that concentration, not a potency): 22.6%
For compound 4 the middle estimate is 7.4 percentage points above the measured one; the measured number falls inside the stated range.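

On the core without the methyl, 1-phenyl-1H-tetrazol-5-yl in place of 4-methyl-4H-1,2,4-triazol-3-yl on a sulfur gives, in this assay, a number 12.9 percentage points lower from compound 3 to compound 4 (beyond the scatter), and the two readings of this change on different cores do not separate: the same change on two cores in this assay, a number 5.6 percentage points lower (within the scatter) from compound 2 to compound 1 and a number 12.9 percentage points lower (beyond the scatter) from compound 3 to compound 4, 7.3 percentage points apart, within the scatter of two such steps. Read the other way round, hydrogen in place of methyl on an aromatic carbon gives a number 0.4 percentage points higher from compound 1 to compound 4 (within the scatter), and this change also carries across the two sulfur substituents without a clear difference: the same change on two cores in this assay, a number 7.7 percentage points higher (within the scatter) from compound 2 to compound 3 and a number 0.4 percentage points higher (within the scatter) from compound 1 to compound 4, 7.3 percentage points apart, within the scatter of two such steps. For the compounds shown here, the four compounds therefore support a sulfur-substituent change that points the same way on both cores, but only one of the two steps lies beyond the scatter, so its size is not fixed, and two cores at one concentration establish neither a general rule for the series nor a potency.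

The compounds shown leave open whether the same carry-over holds with a chlorine or a methoxy group in place of that methyl on an aromatic carbon. They also leave open how an amine or a carboxylic acid would read in place of the 1-phenyl-1H-tetrazol-5-yl and 4-methyl-4H-1,2,4-triazol-3-yl groups on the sulfur.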